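From furan-2-yl to thiophen-2-yl on the shared core

The compounds below may be only part of what the source reports. "The series", "measured", "known", "first", "only" and "open" are said of these compounds alone.

Going by the values given here, in a functional assay on HCT-116 cells (Homo sapiens), read by MTT assay, with a stated time of 72 h (a lower number here means a stronger inhibitor, a higher number a weaker inhibitor), compound 2 `CNc1ncnc2c1c(-c1ccco1)cn2[C@@H]1O[C@H](CO)[C@@H](O)[C@H]1O` gives 230 nM, the only exact number so far. Compound 1 `CSc1ncnc2c1c(-c1cccs1)cn2[C@@H]1O[C@H](CO)[C@@H](O)[C@H]1O` gives > 20000 nM, which is a limit of the assay. Compound 3 `CNc1ncnc2c1c(-c1cccs1)cn2[C@@H]1O[C@H](CO)[C@@H](O)[C@H]1O` has thiophen-2-yl in place of furan-2-yl on an aromatic carbon. Among the compounds with values here, no measured pair shows this exchange on its own, so the expectation starts from compound 2 at 230 nM and assumes no change beyond the scatter in this assay. The expected move is a 1.3-fold higher number from compound 2 to compound 3 (0.12 log units; within the scatter). Compound 3 is estimated at 300 nM, with an expected range of 80 nM to 1200 nM.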

Compound 3, half-maximal inhibitory concentration: > 20000 nM
Compound 3: a limit, no number (the forecaster's own chance of this, stated with the estimate: 8%); middle value at least 66-fold (1.82 log units) away from the limit.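

In this assay thiophen-2-yl in place of furan-2-yl on this aromatic carbon gives an at least 86-fold higher number from compound 2 to compound 3 (1.93 log units; beyond the scatter) and so shows that this position does not tolerate the exchange, although both groups are five-membered aromatic rings with 1 hetero atom. Compound 3 gives > 20000 nM as a limit of the assay. Going by these compounds, the step between compound 1 and compound 3 cannot be read, and the full size of the step from furan-2-yl stays unknown: the limit of > 20000 nM in this assay, at which 2 of the 3 values shown sit.

On these data alone, what phenyl or a plain methyl group would give at this position remains open. So does whether methylsulfanyl in place of methylamino would matter with furan-2-yl on the shared core.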